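The source may hold more compounds than are shown below. What is called first, only, known or untested is meant among the compounds shown, and "the series" means these compounds.

Compound 1, `C/C(=C\Cc1c(O)ccc2c1O[C@H](c1ccc(O)cc1)CC2=O)C/C=C/C(C)(C)O`, carries a side chain ending in a free hydroxyl on a saturated carbon. In a functional assay on HeLa S3 cells (Homo sapiens) for cytotoxicity, read by MTT assay (a higher number here means a weaker inhibitor, a lower number a stronger inhibitor), compound 1 gives only a limit of the assay, > 10000 nM. Compound 2, `COC(C)(C)/C=C/C/C(C)=C/Cc1c(O)ccc2c1O[C@H](c1ccc(O)cc1)CC2=O`, differs from it by a methyl in place of hydrogen on an oxygen on a saturated carbon. In this assay compound 2 likewise gives only a limit of the assay, > 10000 nM. The step from compound 1 to compound 2, a step that the two limits leave unreadable from compound 1 to compound 2, cannot be read, because of the limit of > 10000 nM in this assay, at which 2 of the 2 values shown sit. Compound 3, `C=C(C)C(O)CC/C(C)=C/Cc1c(O)ccc2c1O[C@H](c1ccc(O)cc1)CC2=O`, is not yet measured and differs from compound 2 by 2-hydroxy-3-methylbut-3-en-1-yl in place of 3-methoxy-3-methylbut-1-en-1-yl on a saturated chain carbon bound to a double-bonded chain carbon. Among the compounds with values here, no measured step bears on this change. With compound 2 resting at a limit, the expected step that the limit leaves unreadable from compound 2 to compound 3 has no anchor. Compound 3 is therefore estimated at 20000 nM, within a range of 5000 nM to 100000 nM, and is expected to be reported again as a limit.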

Compound 3, half-maximal inhibitory concentration: > 10000 nM
Compound 3 ended at the assay's limit (the forecaster's own chance of this, stated with the estimate: 80%); the middle value lies beyond the limit too.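

No step among compound 1, compound 2 and compound 3 can be read in this assay, because all three rest at a limit of the assay: the limit of > 10000 nM in this assay, at which 3 of the 3 values shown sit.

The compounds shown leave open how far apart they truly lie, and whether any side chain on the shared core gives a readable value.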